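Compound 3 to compound 4: replacing the trifluoro side chain

The source may report more compounds than this note shows. Statements on the series, on what has been measured and on what is new or still open speak of the compounds shown alone.

Values measured in an in vitro ADME assay on microsomes from Gut (Homo sapiens) for metabolic stability, using NADPH (a lower number here means slower removal, a higher number faster removal of the compound), so far:
- compound 1 `COc1ccc(C)cc1Cn1c(C(=O)NCC(C)(C)CO)cc2cc(C#N)ccc21` gives < 6 mL.min-1.g-1 (a limit of the assay)
- compound 2 `Cc1ccc(C(F)(F)F)cc1Cn1c(C(=O)NCC(C)(C)CO)cc2cc(C#N)ccc21` gives < 6 mL.min-1.g-1 (a limit of the assay)
- compound 3 `N#Cc1ccc2c(c1)cc(C(=O)NCCC(O)C(F)(F)F)n2Cc1cccc(OC(F)(F)F)c1` gives 26 mL.min-1.g-1 (a measured number)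

Among the measured compounds shown here, compound 3 holds the only actual number in the set (26 mL.min-1.g-1). The other two readings are limits. For the measured compounds named here, no measured step between compounds that differ in one place is available for comparison.

The next compound, compound 4 `CC(O)C1(CNC(=O)c2cc3cc(C#N)ccc3n2Cc2cccc(OC(F)(F)F)c2)CCCC1`, keeps the rest of compound 3 and alters one group (a group of 8 heavy atoms (7 carbon, 1 oxygen; one five-membered non-aromatic ring of carbon only) in place of a group of 7 heavy atoms (3 carbon, 1 oxygen, 3 fluorine; no ring), on a saturated chain carbon bound to an amide-type nitrogen). The 3,3,3-trifluoro-2-hydroxypropyl group leaves, and a group with one five-membered non-aromatic ring of carbon only enters on the saturated chain carbon bound to an amide-type nitrogen.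

Going by the values given here, with no step to calibrate against, the expected change in this assay stays within the usual scatter, leaning if anything toward faster removal. The expected step is small (a 1.3-fold higher number from compound 3 to compound 4 (0.13 log units; within the scatter)) and is an estimate only. Compound 4 is estimated at 35 mL.min-1.g-1 (expected range 12 mL.min-1.g-1 to 90 mL.min-1.g-1).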

Compound 4, intrinsic clearance in microsomes: 99 mL.min-1.g-1
The estimate for compound 4 lay 2.8-fold (0.45 log units) below the measured number, and the stated range ends below it.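

In this assay, among the compounds shown here, the place on a saturated chain carbon bound to an amide-type nitrogen now gives the first readable single change: swapping the 3,3,3-trifluoro-2-hydroxypropyl group for the group with one five-membered non-aromatic ring of carbon only gives a 3.8-fold higher number from compound 3 to compound 4 (0.58 log units; beyond the scatter), beyond the scatter. The two groups match in hydrogen-bond donors, hydrogen-bond acceptors and net charge, and differ in fluorine, in the ring and in heavy atoms. The other readings offer no further number to set this step against: the limit of < 6 mL.min-1.g-1 in this assay, at which 2 of the 4 values shown sit.

A single step cannot separate the loss of fluorine from the gain of the ring. On these data alone, how a plain 2-hydroxypropyl chain, or an amine or a carboxylic acid at this place, would read stays open.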